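A few compounds are considered here, and "the series" means these few. Any claim that something is new, unique, unknown or untested is made for them only; others in the source may bear on it.

Going by the values given here, compound 1 `CC1(C)C(CO)CC1Cn1cnc2c(N)nc(N)nc21` is the first of three measured compounds in an ADME assay on L1210/0 cells (Mus musculus) for cytotoxicity, with a stated time of 48 h; on this read-out higher numbers stand for weaker inhibition and lower numbers for stronger inhibition. In this assay compound 1 gives a value that is a limit of the assay, > 200000 nM. Compound 2 `CC1(C)C(CO)CC1Cn1cnc2c(Cl)nc(N)nc21` carries the change chloro in place of amino on an aromatic carbon and its result in this assay is also a limit, > 200000 nM. The step that the two limits leave unreadable from compound 1 to compound 2 cannot therefore be read. Compound 3 `CC1(C)C(CO)CC1Cn1nnc2c(N)nc(N)nc21` has a different core; the difference between the two cores is not broken down here. In this assay compound 3 likewise gives a limit, > 200000 nM. Compound 4 `CC1(C)C(CO)CC1Cn1nnc2c(Cl)nc(N)nc21`, not yet measured, carries the same change as before, (chloro in place of amino on an aromatic carbon). Given (the limit of > 200000 nM in this assay, at which 3 of the 3 values shown sit), the step that the limit leaves unreadable from compound 3 to compound 4 is expected to be unreadable in the same way, and compound 4 is estimated at 250000 nM, between 100000 nM and 600000 nM.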

Compound 4, half-maximal inhibitory concentration: > 200000 nM
Compound 4 was reported as a limit; the forecaster's own chance of this, stated with the estimate: 85%; the middle value does not contradict the limit.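

No new step can be read between compound 3 and compound 4, since both results are limits: the limit of > 200000 nM in this assay, at which 4 of the 4 values shown sit. The compounds shown leave open how strongly any of them inhibits in this assay, and whether chloro in place of amino changes that.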